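Swapping 2-cyanobenzyl for 3-fluorobenzyl on a shared core

The source may report more compounds than this note shows. Statements on the series, on what has been measured and on what is new or still open speak of the compounds shown alone.

Three compounds with one shared core have numbers in a functional assay on B16 cells (Mus musculus) for antiproliferative activity, read by MTT assay, with a stated time of 24 h; a higher number here means a weaker inhibitor, a lower number a stronger inhibitor. Compound 1 `COc1cc(OC)c(-c2coc3cc(OCC=C(C)C)ccc3c2=O)cc1OC` gives 1090 nM, compound 2 `C=CCOc1ccc2c(=O)c(-c3cc(OC)c(OC)cc3OC)coc2c1` gives 5100 nM, and compound 3 `COc1cc(OC)c(-c2coc3cc(OCc4ccccc4C#N)ccc3c2=O)cc1OC` gives 2140 nM. That last value sits close to one neighbour and clear of the other: the steps are a 2.0-fold higher number from compound 1 to compound 3 (0.29 log units; within the scatter) and a 2.4-fold lower number from compound 2 to compound 3 (0.38 log units; beyond the scatter).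

Compound 4 `COc1cc(OC)c(-c2coc3cc(OCc4cccc(F)c4)ccc3c2=O)cc1OC` keeps the core and changes one group: 3-fluorophenyl in place of 2-cyanophenyl on a saturated chain carbon bound to an oxygen on an aromatic ring. For the measured compounds named here, no tested compound carries this new group, so the only guides are the swaps already made at this same place. The largest of them, a 4.7-fold higher number from compound 1 to compound 2 (0.67 log units; beyond the scatter), removed the group's bulk of atoms rather than exchanging one substituted benzene ring for another. Compound 4 keeps such a ring, and the swap here alters only what sits on it. The expected change is therefore small and has no favoured direction in this assay, an estimated 1.1-fold lower number from compound 3 to compound 4 (0.03 log units; within the scatter), which stays within the scatter. For compound 4 the estimate is 2000 nM, with an expected range from 900 nM to 4500 nM.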

Compound 4, half-maximal inhibitory concentration: 2440 nM
The estimate for compound 4 lay 1.2-fold (0.09 log units) below the measured number; low and high end bracket the measured number.
By their numbers in this assay, from the lowest: compounds 1, 3 and 4 (each within the scatter of the next, the first and the last beyond it); then compound 2.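

In this assay, exchanging 2-cyanobenzyl for 3-fluorobenzyl barely registers: a 1.1-fold higher number from compound 3 to compound 4 (0.06 log units; within the scatter) leaves the two compounds indistinguishable, even though the nitrile has gone and a fluorine has arrived at a different spot on the ring. So two differently substituted benzene rings at this place give the same result within the scatter, the first such pair among these compounds. Compound 4 also sits apart from both compounds without a benzene ring in this group, with a 2.1-fold lower number from compound 2 to compound 4 (0.32 log units; beyond the scatter) and a 2.2-fold higher number from compound 1 to compound 4 (0.35 log units; beyond the scatter), both modest and in opposite directions, so the ring-bearing group falls between those two.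

On these data alone, whether an amine or a carboxylic acid on that ring, or a longer chain in place of the benzyl carbon, would shift the number beyond the scatter remains open. No measurement available here accounts for any of these steps.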